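Amino for chloro: working notes on a small series

A few compounds are considered here, and "the series" means these few. Any claim that something is new, unique, unknown or untested is made for them only; others in the source may bear on it.

Measured compounds:
compound 1 `Cc1ccc2c(=O)cc(-c3ccc(Cl)cc3)oc2c1` gives 6830 nM
compound 2 `Cc1ccc2c(=O)cc(-c3ccc(N)cc3)oc2c1` gives 40500 nM
compound 3 `Cc1cc(Cl)cc2c(=O)cc(-c3ccc(Cl)cc3)oc12` gives "not determined" (no result reported)

All numbers come from a functional assay on HepG2 cells (Homo sapiens) for cytotoxicity, read by MTT assay, with a stated time of 48 h; on this read-out lower numbers stand for stronger inhibition and higher numbers for weaker inhibition. Compound 1 and compound 2 share one core and differ only by amino in place of chloro on an aromatic carbon. The step of a 5.9-fold higher number from compound 1 to compound 2 (0.77 log units; beyond the scatter) is modest but lies beyond the usual scatter of repeated runs, so compound 2 stands at a higher number than compound 1 in this assay.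

Compound 3 carries a second core; how it differs from the core of compound 1 is not broken down here. Within the data shown here, compound 3 has no number in this assay, so no step from it to anything can be given.

Compound 4 `Cc1cc(Cl)cc2c(=O)cc(-c3ccc(N)cc3)oc12` has not been measured. It differs from compound 3 by amino in place of chloro on an aromatic carbon. The place of the change in compound 4 reads the same, word for word, as in compound 2, so this is the same change made on the second core. Among the measured compounds shown here, the only guide to its size is the one measured case, a 5.9-fold higher number from compound 1 to compound 2 (0.77 log units; beyond the scatter), and the only anchor for its level is compound 2, because compound 2 gives 40500 nM while compound 3 has no value of its own. The expectation is therefore loose. Compound 4 is expected to come out near 38000 nM, with a range from 10000 nM to 130000 nM.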

Compound 4, half-maximal inhibitory concentration: 11900 nM
Beside the measured number, compound 4's estimate is 3.2-fold (0.50 log units) above it; the range from low to high includes it.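

In this assay, among these compounds, compound 4 gives 11900 nM, but compound 3 has no value to set against it, so no step from compound 3 to compound 4 can be read. The compounds shown leave open whether amino in place of chloro moves the number on the core of compound 3 as it does on the core of compound 1. No evidence on hand bears on this result.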